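From compound 2 to compound 3: one fluoro

The source may report more compounds than this note shows. Statements on the series, on what has been measured and on what is new or still open speak of the compounds shown alone.

In an ADME assay on MT4 cells (Homo sapiens) for cytotoxicity, read by MTT assay (a lower number here means that less compound is tolerated, a higher number that more compound is tolerated), compound 1 (`O=C1NC(=O)C(C(=O)NCc2ccc(F)cc2)c2ccccc21`) reaches only the limit of the assay at > 250000 nM and gives no number. Within the data shown here, compound 2 (`O=C(NCc1ccccc1)C1C(=O)N(O)C(=O)c2ccccc21`) gives 130000 nM in this assay and so holds the only actual number available. Compound 3 (`O=C(NCc1ccc(F)cc1)C1C(=O)N(O)C(=O)c2ccccc21`) differs from compound 2 by fluoro in place of hydrogen on an aromatic carbon, para to a large group (fluoro in place of hydrogen on an aromatic carbon). Among the measured compounds shown here, no measured step shows what such a change does, so no shift beyond the usual scatter is expected in this assay, in either direction. The estimated 1.0-fold lower number from compound 2 to compound 3 (0.02 log units; within the scatter) is accordingly small. Compound 3 is expected at 125000 nM with an estimated range from 60000 nM to 240000 nM as its bounds.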

Compound 3, half-maximal cytotoxic concentration: 202000 nM
For compound 3 the middle estimate is 1.6-fold (0.21 log units) below the measured one; measured number inside the range.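

In this assay, among these compounds, fluoro in place of hydrogen gives the first measured step at this position, a 1.6-fold higher number from compound 2 to compound 3 (0.19 log units; within the scatter), so this change does not separate the two compounds. Hydroxy in place of hydrogen on an amide-type nitrogen in a ring gives an at least 1.2-fold lower number from compound 1 to compound 3 (0.09 log units; that floor lies within the scatter), which is only a floor. Compound 1 stands at a limit of the assay and not at a number: the limit of > 250000 nM in this assay, at which 1 of the 3 values shown sits.

Going by these compounds, the true size of the hydroxy step stays open. So does whether a chloro or methoxy group at this place, or a longer chain in place of benzyl, would move the number beyond the scatter.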